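Aryl amide change from compound 2 to compound 3

The source may report more compounds than this note shows. Statements on the series, on what has been measured and on what is new or still open speak of the compounds shown alone.

In a functional assay on NCI-H460 cells (Homo sapiens) for inhibition, read by CCK-8 assay, with a stated time of 72 h, tested at 1 uM (a higher number here means more inhibition of growth at the concentration tested, a lower number less inhibition of growth), compound 1 `CN(C)C(=O)c1cc2cnc(Nc3ccc(NC(=O)C4(C(=O)Nc5ccc(F)cc5)CC4)cc3)nc2n1C1CCCC1` gives 79.9% and compound 2 `CN(C)C(=O)c1cc2cnc(Nc3ccc(NC(=O)C4(C(=O)Nc5cccc(O)c5)CC4)cc3)nc2n1C1CCCC1` gives 75.5%, two values within the scatter of each other. Compound 3 `CN(C)C(=O)c1cc2cnc(Nc3ccc(NC(=O)C4(C(=O)Nc5ccccc5F)CC4)cc3)nc2n1C1CCCC1` is reached from compound 2 by 2-fluorophenyl in place of 3-hydroxyphenyl on an amide-type nitrogen, with 2-fluorophenyl in place of 3-hydroxyphenyl on an amide-type nitrogen. Going by the values given here, only one measured step bears on this place: a number 4.4 percentage points lower from compound 1 to compound 2 (within the scatter), a step within the scatter. Among the compounds with values here, no 2-fluorophenyl member has been measured, so no step beyond the scatter is expected. The expected change is a number 0.5 percentage points higher from compound 2 to compound 3 (within the scatter). For compound 3 the estimated value is 76%, with an expected range of 62% to 88%.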

Compound 3, percent growth inhibition at one concentration: 28.2%
For compound 3 the middle estimate is 47.8 percentage points above the measured one; measured number outside the range, below it.
By their numbers in this assay, from the lowest: compound 3; then compounds 2 and 1 (each within the scatter of the next).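

In this assay, the aryl group on the amide-type nitrogen turns out not to be tolerant of every change: 2-fluorophenyl gives a number 47.3 percentage points lower from compound 2 to compound 3 (beyond the scatter) and a number 51.7 percentage points lower from compound 1 to compound 3 (beyond the scatter). The second step swaps 4-fluorophenyl for 2-fluorophenyl, so the same substituent at a different ring place is enough to separate these compounds, which the earlier pair did not show. Nothing available explains the loss. Going by these compounds, whether it is specific to fluorine stays open; 2-chlorophenyl, 2-methylphenyl or 2-hydroxyphenyl would test this. On these data alone, the standing of 3-fluorophenyl also remains open.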